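Fluoro in place of chloro on compound 3

The compounds below may be only part of what the source reports. "The series", "measured", "known", "first", "only" and "open" are said of these compounds alone.

In a functional assay on U-87MG ATCC cells (Homo sapiens) for cytotoxicity, read by MTT assay, with a stated time of 48 h (on this read-out lower numbers stand for stronger inhibition and higher numbers for weaker inhibition), compound 3 (`CC(=NNC(=S)Nc1ccc(Cl)cc1)c1ccccn1`) gives 1.7 nM, the lowest of the three numbers. Compound 1 (`C/C(=N\NC(=S)Nc1ccc(F)cc1)c1ccccn1`) gives 10 nM and compound 2 (`C/C(=N/NC(=S)Nc1ccc(F)cc1)c1ccccn1`) gives 10 nM, both higher than compound 3 and beyond the scatter. Compound 4 (`CC(=NNC(=S)Nc1ccc(F)cc1)c1ccccn1`) departs from compound 3 by fluoro in place of chloro on an aromatic carbon. The measured step that bears on this is no change at the digits printed from compound 1 to compound 2 (within the scatter), within the scatter, and it comes with the fact that compounds 1 and 2 differ only in the configuration as drawn. Compound 4 shares the atoms and bonds of compound 1 and compound 2, with no configuration drawn, so it is expected to sit with them. The expected 5.9-fold higher number from compound 3 to compound 4 (0.77 log units; beyond the scatter) is a rise beyond the scatter, towards weaker inhibition. For compound 4 the estimated value is 10 nM, within a range of 6 nM to 17 nM.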

Compound 4, half-maximal inhibitory concentration: 10 nM
For compound 4 middle estimate and measured number coincide at the digits printed; low and high end bracket the measured number.
By their numbers in this assay, from the lowest: compound 3; then compounds 1, 2 and 4 (each within the scatter of the next).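

In this assay, fluoro in place of chloro on an aromatic carbon para to a large group gives a 5.9-fold higher number from compound 3 to compound 4 (0.77 log units; beyond the scatter) and so shows that this position responds to the halogen it carries. The drawing of the double bond does not separate the fluoro compounds, with no change at the digits printed from compound 1 to compound 4 (within the scatter) and no change at the digits printed from compound 2 to compound 4 (within the scatter) as well. Compound 3 therefore remains lower than compound 4 whichever way the latter is drawn.

From the compounds shown here alone, how a bromo, methyl or methoxy group would fare at this position remains open. So does whether the chloro compound would match across defined double-bond configurations, as the fluoro compounds do.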